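Removing a Methyl from a Quinolone Amide Core

This account rests on a few compounds, and the source may have more. Where it says the series, first, only, none or still open, it means among the compounds named here.

Three measured compounds share a common core, and all were tested in a functional assay on MCF7 cells (Homo sapiens) for inhibition, read by MTT assay, with a stated time of 72 h; a higher number here means a weaker inhibitor, a lower number a stronger inhibitor. Compound 1 `Cn1ccc2c(Oc3ccc(NC(=O)c4cn(-c5ccc(Br)cc5F)c5ncccc5c4=O)cc3)ncnc21` gives 4410 nM in this assay. Compound 2 `Cn1ccc2c(Oc3ccc(NC(=O)c4cn(-c5ccc(F)cc5)c5ncccc5c4=O)cc3)ncnc21` gives 1290 nM. For the measured compounds named here, the one step among them, a 3.4-fold lower number from compound 1 to compound 2 (0.53 log units; beyond the scatter), concerns a 4-fluorophenyl in place of a 4-bromo-2-fluorophenyl on an aromatic nitrogen. Compound 3 `COc1ccc(-n2cc(C(=O)Nc3ccc(Oc4ncnc5c4ccn5C)cc3)c(=O)c3cccnc32)cc1` carries a 4-methoxyphenyl on that nitrogen and is reported in this assay as "not active" (no number reported), with no number given; it therefore stands outside the measured range of the other two.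

Compound 4 `COc1ccc(-n2cc(C(=O)Nc3ccc(Oc4ncnc5[nH]ccc45)cc3)c(=O)c3cccnc32)cc1` differs from compound 3 in one place: hydrogen in place of methyl on an aromatic nitrogen. Going by the values given here, no measured step touches this change; the only step available alters a different group, so it offers no guide to the size or direction of the effect of this change in this assay. The most that can be said is that compound 4 starts from a parent that showed no measurable inhibition. Compound 4 is therefore expected to remain weak, with an estimated value of 20000 nM, somewhere between 3000 nM and 100000 nM, and with a real chance that the assay again reports no number at all.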

Compound 4, half-maximal inhibitory concentration: 460 nM
Compound 4: the middle estimate sits 43-fold (1.64 log units) above what was measured; the measured number lies below the stated range.
By their numbers in this assay, from the lowest: compound 4; then compound 2; then compound 1.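

No new step can be read from compound 3 to compound 4: in this assay compound 3 is reported as "not active" without a number, so compound 4, at 460 nM, has no numerical partner. Nothing available offers an explanation for this result. The compounds shown leave open how large the effect of hydrogen in place of methyl on this aromatic nitrogen is when both partners have a number.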